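The source may hold more compounds than are shown below. What is called first, only, known or untested is meant among the compounds shown, and "the series" means these compounds.

Compound 1 `CCN(CC)CN1C(=O)/C(=N/NC(=S)Nc2ccccc2)c2cc(Cl)ccc21` and compound 2 `CCN(CC)CN1C(=O)/C(=N/NC(=S)Nc2ccc(Cl)cc2)c2ccccc21` share one core and differ in where a chlorine sits. Both were tested in an ADME assay on HEL cells (Homo sapiens) for cytotoxicity (on this read-out lower numbers stand for higher toxicity in this test and higher numbers for lower toxicity in this test), a test of how much of a compound a cell culture tolerates before damage appears. In this assay compound 1 gives 100000 nM. In this assay compound 2 gives 100000 nM. Compound 1 thus stands level with compound 2 at the digits shown; the two values lie within the usual scatter of this test, so neither can be called more or less toxic than the other.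

The untested compound 3 `CCN(CC)CN1C(=O)/C(=N/NC(N)=S)c2cc(Cl)ccc21` keeps the core of compound 1 and differs in one place: hydrogen in place of phenyl on an amide-type nitrogen. The same change, seen one bond further out, reads anilino to amino.

For the measured compounds named here, no measured pair shows what this change does in this assay. Since compound 1 and compound 2 both sit at the upper end of the read-out, the step from compound 1 to compound 3 is expected to be none beyond the scatter, as no change at the digits printed from compound 1 to compound 3 (within the scatter). For compound 3 in this assay a value of 100000 nM is estimated, within a range of 50000 nM to 200000 nM.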

Compound 3, minimum cytotoxic concentration: > 100000 nM
Compound 3 gave a limit, no number (the forecaster's own chance of this, stated with the estimate: 40%); the middle value sits exactly at the limit.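

For the compounds shown here, this is the first step at the amide-type nitrogen, where hydrogen takes the place of phenyl, and it gives a number no lower from compound 1 to compound 3 (the limit leaves the size open). In this assay compound 3 gives > 100000 nM, which is a limit of the test and not a number. The change therefore shows that the phenyl on this nitrogen is not needed for a reading this high, and that removing all of its carbon atoms does not move the value downward. How large the step really is cannot be told because the reading stops at the limit of the test: the limit of > 100000 nM in this assay, at which 1 of the 3 values shown sits.

The compounds shown leave open whether any group on this nitrogen would bring the value down into the measurable range, for example a small methyl, a longer chain such as n-butyl, or a carboxylic acid on a short chain. They also leave open whether hydrogen and phenyl behave alike here on a different core, since only the core of compound 1 carries this change.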